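This account rests on a few compounds, and the source may have more. Where it says the series, first, only, none or still open, it means among the compounds named here.

Measured compounds in a functional assay on CHO cells for positive allosteric modulation of metabotropic glutamate receptor 2 (Homo sapiens), read by scintillation counting and GTPgammaS binding, with a stated time of 30 min; a lower number here means a smaller maximal response, a higher number a larger maximal response:

compound 1 `CCCCn1ccc(-c2ccc(Oc3ccnc(C)c3)cc2)c(C#N)c1=O` — 243%
compound 2 `CCCCn1ccc(-c2ccc(Oc3cccnc3C)cc2)c(C#N)c1=O` — 228%
compound 3 `CCCCn1ccc(-c2ccc(Oc3ccnc(C)c3)c(Cl)c2)c(C#N)c1=O` — 245%

Compound 3 sits at the upper end of the three numbers; its value and that of compound 1 lie together within the scatter, so no order between them is claimed, while the step of a number 2 percentage points higher from compound 1 to compound 3 (within the scatter) shows that chloro in place of hydrogen on an aromatic carbon left the maximal response essentially unchanged. Compound 2 stands apart: a number 15 percentage points lower from compound 1 to compound 2 (beyond the scatter) is a modest fall beyond the scatter.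

Compound 4 `CCCCn1ccc(-c2ccc(Oc3cccnc3C)c(Cl)c2)c(C#N)c1=O` is the unmeasured member. It differs from compound 3 as follows: 2-methylpyridin-3-yl in place of 2-methylpyridin-4-yl on an oxygen on an aromatic ring

This is the same exchange at the same oxygen that separates compound 1 from compound 2, now carried out on the chloro-bearing core of compound 3. Within the data shown here, the one directly relevant precedent is therefore a number 15 percentage points lower from compound 1 to compound 2 (beyond the scatter); the precedent a number 2 percentage points higher from compound 1 to compound 3 (within the scatter) indicates that the chloro present in compound 3 and compound 4 does not by itself shift the read-out. A modest decrease, of roughly the size seen in a number 15 percentage points lower from compound 1 to compound 2 (beyond the scatter), is expected for compound 4, that is a number 15 percentage points lower from compound 3 to compound 4 (beyond the scatter). Compound 4 is accordingly estimated at 230%, with a range of 208% to 252%.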

Compound 4, largest response reached (Emax), in percent of the reference or control that the assay uses: 236%
Compound 4: the middle estimate sits 6 percentage points below what was measured; measured number inside the range.
By their numbers in this assay, from the lowest: compounds 2, 4, 1 and 3 (each within the scatter of the next, the first and the last beyond it).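

On the chloro-bearing core, 2-methylpyridin-3-yl in place of 2-methylpyridin-4-yl on the oxygen gives a number 9 percentage points lower from compound 3 to compound 4 (within the scatter), so in this assay this exchange stays within the scatter here, whereas it went beyond the scatter on the core without chloro. That contrast does not establish a dependence on the core: the same change on two cores in this assay, a number 15 percentage points lower (beyond the scatter) from compound 1 to compound 2 and a number 9 percentage points lower (within the scatter) from compound 3 to compound 4, 6 percentage points apart, within the scatter of two such steps. Chloro in place of hydrogen gives a number 8 percentage points higher from compound 2 to compound 4 (within the scatter), so this change now stays within the scatter with both methylpyridinyl groups: the same change on two cores in this assay, a number 2 percentage points higher (within the scatter) from compound 1 to compound 3 and a number 8 percentage points higher (within the scatter) from compound 2 to compound 4, 6 percentage points apart, within the scatter of two such steps.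

The compounds shown leave open how the maximal response behaves with a fluoro or a methoxy in place of the chloro. Going by these compounds, it is also open whether a phenyl group in place of the methylpyridinyl groups on the oxygen would keep the maximal response within this range.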